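Nitrophenyl for ethoxycarbonyl on the ether-linked chain of compound 2

The source may report more compounds than this note shows. Statements on the series, on what has been measured and on what is new or still open speak of the compounds shown alone.

Working notes on the series. Compound 1 `CCOC(=O)c1c(C)nc(-c2ccccc2)n1OC` carries the shared core with a methoxy group on the ring nitrogen; in a functional assay on a cell-free system (plasma, Oryctolagus cuniculus) for inhibition, with stated times of 5 min, 1 min and 6 min (a higher number here means a weaker inhibitor, a lower number a stronger inhibitor), compound 1 gives only a limit of the assay, > 30000 nM. Within the data shown here, compound 2 `CCOC(=O)COn1c(-c2cccc(C#N)c2)nc(C)c1C(=O)OCC` bears a nitrile on the phenyl ring and an (ethoxycarbonyl)methyl chain on the oxygen; in this assay compound 2 gives 6800 nM, which is the only real number among the three values shown. Compound 3 `CCOC(=O)c1c(C)nc(-c2cccc(C#N)c2)n1OCCC(=O)O` is the acid analogue; in this assay compound 3 gives only a limit of the assay, > 30000 nM. Among the measured compounds shown here, the one measured step, an at least 4.4-fold higher number from compound 2 to compound 3 (0.64 log units; beyond the scatter), is the sole guide to what the chain beyond the oxygen tolerates, and it ends at the limit of > 30000 nM in this assay, at which 2 of the 3 values shown sit.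

Compound 4 `CCOC(=O)c1c(C)nc(-c2cccc(C#N)c2)n1OCc1ccc([N+](=O)[O-])cc1` is the next variant. It differs from compound 2 as follows: 4-nitrophenyl in place of ethoxycarbonyl on a saturated chain carbon bound to an oxygen on an aromatic ring. For the measured compounds named here, no measured step covers this exchange; the step from compound 2 to compound 3 shows only that an acid at that place costs potency, and 4-nitrophenyl is neither an ester nor an acid. The expectation for this assay is therefore a step that is small to modest and most likely toward a higher number, a 1.5-fold higher number from compound 2 to compound 4 (0.17 log units; within the scatter), with a real chance of the limit. For compound 4 the estimate in this assay is 10000 nM, expected between 2500 nM and 30000 nM.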

Compound 4, half-maximal inhibitory concentration: 8750 nM
Estimate against measurement, compound 4: 1.1-fold (0.06 log units) above; low and high end bracket the measured number.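

In this assay, among these compounds, the exchange of the ethoxycarbonyl for 4-nitrophenyl gives a 1.3-fold higher number from compound 2 to compound 4 (0.11 log units; within the scatter), so on a saturated chain carbon bound to an oxygen on an aromatic ring, an ester is not the only group that keeps a measurable number: a six-membered aromatic ring of carbon only serves as well within the scatter. Set against the acid, the same chain end gives an at least 3.4-fold lower number from compound 3 to compound 4 (0.53 log units; beyond the scatter), which places the loss seen so far with the carboxymethyl group alone and not with every change to the ethoxycarbonyl. Compound 3 gives only a limit of the assay, so this step is a bound and not a size: the limit of > 30000 nM in this assay, at which 2 of the 4 values shown sit.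

On these data alone, whether the nitro group of the 4-nitrobenzyl chain plays any part stays open, and a plain benzyl or a 4-aminobenzyl chain would speak to that, as would an amide in place of the ester or a longer chain carrying the ethoxycarbonyl. As far as these compounds go, the share of the nitrile also stays open, since compound 1 differs from compound 2 in more than one place and the two cannot be compared directly.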